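The source may hold more compounds than are shown below. What is called first, only, known or untested is meant among the compounds shown, and "the series" means these compounds.

Measured so far:
compound 1, `O=C(O)c1cc(/C=C(\C(=O)c2c(F)c(F)c(F)c(F)c2F)S(=O)(=O)c2ccc(Br)cc2)ccc1O`, > 100000 nM
compound 2, `COc1ccccc1/C=C(/SCc1ccc(F)cc1)C(=O)c1ccc(Cl)cc1`, 10000 nM
compound 3, `Cc1ccc(CS(=O)(=O)/C(=C/c2cccc(Cl)c2Cl)C(=O)c2ccc(Cl)cc2)cc1`, 1000 nM

In a functional assay on DU-145 cells (Homo sapiens) for inhibition, read by trypan blue exclusion, with a stated time of 96 h (a lower number here means a stronger inhibitor of growth, a higher number a weaker inhibitor of growth), compound 1 gives > 100000 nM, and this is a limit of the assay rather than a number, so compound 1 stands at the edge of what was measured (the limit of > 100000 nM in this assay, at which 1 of the 3 values shown sits). Compound 2 gives 10000 nM in this assay and compound 3 gives 1000 nM; both have a different core from compound 1, so their values show only that each of them was measurable where compound 1 was not.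

Compound 4, `O=C(/C(=C\c1ccc([N+](=O)[O-])c(O)c1)S(=O)(=O)c1ccc(Br)cc1)c1c(F)c(F)c(F)c(F)c1F`, keeps the core of compound 1 and differs from it by 3-hydroxy-4-nitrophenyl in place of 3-carboxy-4-hydroxyphenyl on a double-bonded chain carbon bound to a double-bonded chain carbon. The 3-carboxy-4-hydroxyphenyl leaves and the 3-hydroxy-4-nitrophenyl enters at the same place on the chain.

No measured step of this kind exists among the compounds shown, so the size of the change can only be guessed. The step of an at least 2.0-fold lower number from compound 1 to compound 4 (0.30 log units; that floor lies within the scatter) is expected to be modest, toward stronger inhibition, but with a real chance that compound 4 also reports only a limit. Compound 4 is expected to give 50000 nM in this assay, within a range from 10000 nM to 200000 nM.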

Compound 4, concentration for 50% growth inhibition: 1000 nM
Compound 4: the middle estimate sits 50-fold (1.70 log units) above what was measured, outside the stated range (below it).
By their numbers in this assay, from the lowest: compounds 3 and 4 (each within the scatter of the next); then compound 2. At a limit, above all of these: compound 1.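

In this assay compound 1 gives > 100000 nM, which is a limit of the assay and not a number. The earlier compounds shown here offered no pair differing in one place, but putting 3-hydroxy-4-nitrophenyl in place of 3-carboxy-4-hydroxyphenyl, on a double-bonded chain carbon bound to a double-bonded chain carbon, gives an at least 100-fold lower number from compound 1 to compound 4 (2.00 log units; beyond the scatter), so with the rest of the core unchanged, this one place is enough to turn a compound with no measurable value into one with a measurable value. The step can be read only as a minimum, and its full size stays unknown because one end of it is not a number: the limit of > 100000 nM in this assay, at which 1 of the 4 values shown sits.

The change alters the ring in more than one way at once, so the compounds shown cannot say whether the step comes from losing the carboxy group, gaining the nitro group or the hydroxy group standing at a different ring number. Nor do they say whether an amine or a nitrile in place of the nitro group would keep this growth inhibition, or whether the same swap would have a similar effect on a different core.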